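The source may hold more compounds than are shown below. What is called first, only, known or untested is meant among the compounds shown, and "the series" means these compounds.

Compound 1 `CC(C)[C@H](C(=O)Nc1ccc(F)cn1)c1ccc(Cl)cc1` and compound 2 `CC(C)[C@H](C(=O)Nc1nc2cc(Cl)ccc2o1)c1ccc(Cl)cc1` share a core and differ only in the group carried by the amide nitrogen. In a functional assay on CHO cells for agonist activity at Free fatty acid receptor 2 (Homo sapiens), read by cAMP accumulation (a lower number here means a smaller maximal response, a higher number a larger maximal response), compound 1 gives 93%, the higher of the two numbers recorded, while compound 2 gives 88%; the gap between them lies within the scatter, so neither stands apart. Compound 3 `Cc1csc(NC(=O)[C@H](c2ccc(Cl)cc2)C(C)C)n1` changes the same position: 4-methyl-1,3-thiazol-2-yl in place of 5-fluoropyridin-2-yl on an amide-type nitrogen. With two different groups at that nitrogen both giving large responses, the step of a number 5 percentage points lower from compound 1 to compound 3 (within the scatter) in this assay is expected to stay within the scatter. Compound 3 is therefore estimated at 88%, in the range 72% to 100%.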

Compound 3, largest response reached (reported as efficacy), in percent of the reference or control that the assay uses: 87%
Compound 3: the middle estimate sits 1 percentage points above what was measured, within the range that was stated.
By their numbers in this assay, from the lowest: compounds 3, 2 and 1 (each within the scatter of the next).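

In this assay, placing 4-methyl-1,3-thiazol-2-yl on the amide-type nitrogen instead of 5-fluoropyridin-2-yl gives a number 6 percentage points lower from compound 1 to compound 3 (within the scatter). A five-membered aromatic ring with two hetero atoms can therefore replace a six-membered one with one hetero atom while the maximal response stays within the scatter. Nothing available here explains why the response holds.

Every group shown at this nitrogen is an aromatic ring. From the compounds shown here alone, whether a saturated cyclohexyl ring or an open ethyl chain would keep so large a response remains open.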